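Methoxy for chloro on the aryl of the shared core

A few compounds are considered here, and "the series" means these few. Any claim that something is new, unique, unknown or untested is made for them only; others in the source may bear on it.

Compound 1 `COc1cc(/C=C/C(=O)c2cccc(-n3cc(-c4ccc(Cl)cc4)[nH]c3=O)c2)cc(OC)c1OC` stands at the higher of the two numbers shown: in a functional assay on NCI-H460 cells (Homo sapiens) for inhibition (a lower number here means a stronger inhibitor of growth, a higher number a weaker inhibitor of growth), compound 1 gives 3740 nM. Compound 2 `O=C(/C=C/c1cccc(O)c1)c1cccc(-n2cc(-c3ccc(Cl)cc3)[nH]c2=O)c1` gives 2410 nM in this assay, a gap within the scatter, so no order between compound 1 and compound 2 can be read from these values. Compound 3 `COc1ccc(-c2cn(-c3cccc(C(=O)/C=C/c4cc(OC)c(OC)c(OC)c4)c3)c(=O)[nH]2)cc1` differs from compound 1 by methoxy in place of chloro on an aromatic carbon, that is, 4-chlorophenyl to 4-methoxyphenyl. Among the compounds with values here, no measured pair carries this change, so nothing beyond the scatter is expected in this assay in either direction. Compound 3 is estimated at 3200 nM, with a range from 1200 nM to 8500 nM. The expected step of a 1.2-fold lower number from compound 1 to compound 3 (0.07 log units; within the scatter) is small.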

Compound 3, concentration for 50% growth inhibition: 1560 nM
The estimate for compound 3 lay 2.1-fold (0.31 log units) above the measured number; the measured number falls inside the stated range.
By their numbers in this assay, from the lowest: compounds 3, 2 and 1 (each within the scatter of the next, the first and the last beyond it).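

The change from 4-chlorophenyl to 4-methoxyphenyl gives a 2.4-fold lower number from compound 1 to compound 3 (0.38 log units; beyond the scatter) in this assay, so this place on the shared core responds to substitution, which the earlier pair of compounds could not show. This reading rests on a single pair of compounds. Nothing on hand accounts for the step.

Open, going by these compounds, is whether a hydroxy, a methyl or a dimethylamino group at the same place would move the number further. Also open, on these data alone, is whether the same change holds on the core of compound 2.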